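The source may hold more compounds than are shown below. What is called first, only, known or untested is meant among the compounds shown, and "the series" means these compounds.

Measured in a functional assay on HeLa cells (Homo sapiens) for inhibition, read by CCK-8 assay, with a stated time of 48 h; on this read-out lower numbers stand for stronger inhibition and higher numbers for weaker inhibition:
- compound 1 `COc1cc(-c2ccnc3cc(-c4c[nH]c5ccccc45)nn23)cc(OC)c1OC`: 195 nM
- compound 2 `COc1cc(-c2ccnc3cc(-c4ccccc4)nn23)cc(OC)c1OC`: 458 nM
- compound 3 `COc1cc(-c2ccnc3cc(-c4ccc(C(C)=O)cc4)nn23)cc(OC)c1OC`: 1810 nM

Compound 3 has the highest number of the three, so it is the weakest in this assay. The move to compound 4 `COc1cc(-c2ccnc3cc(-c4ccc5ccn(C)c5c4)nn23)cc(OC)c1OC` is 1-methyl-1H-indol-6-yl in place of 4-acetylphenyl on an aromatic carbon. Within the data shown here, three measured steps bear on it, all modest: a 4.0-fold higher number from compound 2 to compound 3 (0.60 log units; beyond the scatter) on adding acetyl, a 2.3-fold higher number from compound 1 to compound 2 (0.37 log units; beyond the scatter) on losing the 1H-indol-3-yl, and a 9.3-fold higher number from compound 1 to compound 3 (0.97 log units; beyond the scatter) across both changes. The acetyl is gone in compound 4, and an indole returns, though 1-methyl-1H-indol-6-yl differs from the 1H-indol-3-yl group of compound 1. A modest move to a lower number is therefore expected, with the estimated step being a 5.2-fold lower number from compound 3 to compound 4 (0.71 log units; beyond the scatter). For compound 4 the expected value is 350 nM, within an estimated range of 90 nM to 1300 nM.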

Compound 4, half-maximal inhibitory concentration: 187 nM
Compound 4: middle estimate off by 1.9-fold (0.27 log units), on the high side; the range from low to high includes it.
By their numbers in this assay, from the lowest: compounds 4 and 1 (each within the scatter of the next); then compound 2; then compound 3.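

In this assay, on the aromatic carbon of the five-membered aromatic ring, 1-methyl-1H-indol-6-yl improves on both monocyclic aryl groups: a 9.7-fold lower number from compound 3 to compound 4 (0.99 log units; beyond the scatter) and a 2.4-fold lower number from compound 2 to compound 4 (0.39 log units; beyond the scatter). Against 1H-indol-3-yl it gives a 1.0-fold lower number from compound 1 to compound 4 (0.02 log units; within the scatter), so these two indole groups cannot be told apart on this read-out. No evidence on the cause of these steps is available.

Still open, from the compounds shown here alone, is what the methyl on the indole nitrogen contributes by itself. Also open, going by these compounds, is how an amine or a carboxylic acid on 1-methyl-1H-indol-6-yl would read.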